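This account rests on a few compounds, and the source may have more. Where it says the series, first, only, none or still open, it means among the compounds named here.

Compound 1 `CN1CCN(c2ccc(S(=O)(=O)Oc3ccc(F)cc3)cc2)C1=O` gives, in a functional assay on MCF7 cells (Homo sapiens) for antiproliferative activity, read by sulforhodamine B assay, with a stated time of 48 h (on this read-out lower numbers stand for stronger inhibition and higher numbers for weaker inhibition), only a limit of the assay, > 100000 nM. Compound 2 `CN1CCN(c2ccc(S(=O)(=O)Oc3ccc(Cl)cc3)cc2)C1=O` likewise gives only a limit in this assay, > 100000 nM. Compound 3 `CCCN1CCN(c2ccc(S(=O)(=O)Oc3cccc(F)c3)cc2)C1=O` gives in this assay 24000 nM.

The unmeasured compound 4 `CCCN1CCN(c2ccc(S(=O)(=O)Oc3cccc(Cl)c3)cc2)C1=O` differs from compound 3 by chloro in place of fluoro on an aromatic carbon. The same kind of change was made from compound 1 to compound 2, (chloro in place of fluoro on an aromatic carbon), where the place is para to a large group rather than meta to a large group; there it gave a step that the two limits leave unreadable from compound 1 to compound 2, a step that cannot be read because the limit of > 100000 nM in this assay, at which 2 of the 3 values shown sit, holds both ends. The difference between the cores of compound 1 and compound 3 is not broken down here. With no readable precedent, compound 4 is expected to stay close to compound 3, a step of about a 1.6-fold lower number from compound 3 to compound 4 (0.20 log units; within the scatter). The estimate for compound 4 in this assay is 15000 nM, expected between 5000 nM and 50000 nM.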

Compound 4, half-maximal inhibitory concentration: 380 nM
Estimate against measurement, compound 4: 39-fold (1.60 log units) above; the whole stated range lies above it.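

In this assay, chloro in place of fluoro, meta to a large group, gives a 63-fold lower number from compound 3 to compound 4 (1.80 log units; beyond the scatter), so on this core the change is large. The same change on the core of compound 1 offers no comparison, as the steps there cannot be read: the limit of > 100000 nM in this assay, at which 2 of the 4 values shown sit. The result therefore shows that this change can matter greatly on one core, but not whether it carries over to another, and the two pairs also differ in where the halogen sits on the ring.

The compounds shown leave open what chloro would give on the core of compound 3 at the ring place it holds in compound 2. They also leave open whether bromo or methoxy in that meta place would match chloro.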